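Adding one chloro to compound 2

This account rests on a few compounds, and the source may have more. Where it says the series, first, only, none or still open, it means among the compounds named here.

In a functional assay on SK-MEL-2 cells (Homo sapiens) for inhibition, read by sulforhodamine B assay, with a stated time of 48 h (a higher number here means a weaker inhibitor of growth, a lower number a stronger inhibitor of growth), compound 1 `COc1cc(-c2nn(-c3cccc(NC(=O)Nc4ccc(Cl)c(Cl)c4)c3)cc2-c2ccncc2)ccc1Cl` gives 1140 nM and compound 2 `COc1cc(-c2nn(-c3cccc(NC(=O)Nc4cccc(C(F)(F)F)c4)c3)cc2-c2ccncc2)ccc1Cl` gives 970 nM, so compound 2 stands level with compound 1, not clear of it. Compound 3 `COc1cc(-c2nn(-c3cccc(NC(=O)Nc4ccc(Cl)c(C(F)(F)F)c4)c3)cc2-c2ccncc2)ccc1Cl` differs from compound 2 in one place: chloro in place of hydrogen on an aromatic carbon. This turns 3-(trifluoromethyl)phenyl into 4-chloro-3-(trifluoromethyl)phenyl. For the measured compounds named here, the only measured step bearing on this group is a 1.2-fold lower number from compound 1 to compound 2 (0.07 log units; within the scatter), which exchanges 3,4-dichlorophenyl for 3-(trifluoromethyl)phenyl. No step beyond the scatter is therefore expected in this assay. The estimate amounts to a 1.0-fold lower number from compound 2 to compound 3 (0.01 log units; within the scatter). Compound 3 is expected at 950 nM, with an estimated range of 480 nM to 1900 nM.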

Compound 3, concentration for 50% growth inhibition: 1010 nM
Estimate against measurement, compound 3: 1.1-fold (0.03 log units) below; the measured number falls inside the stated range.
By their numbers in this assay, from the lowest: compounds 2, 3 and 1 (each within the scatter of the next).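

In this assay, placing a chloro ortho to the trifluoromethyl group gives a 1.0-fold higher number from compound 2 to compound 3 (0.02 log units; within the scatter), so this carbon accepts a chloro with no readable shift in growth inhibition. Trifluoromethyl in place of chloro on an aromatic carbon gives a 1.1-fold lower number from compound 1 to compound 3 (0.05 log units; within the scatter), so that exchange, too, stays inside the scatter. No measurement offered here accounts for these results. On these data alone, what an amine or a carboxylic acid would do in place of this chloro remains open. So does whether any group at this carbon can produce a step beyond the scatter.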